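The source may hold more compounds than are shown below. What is called first, only, known or untested is meant among the compounds shown, and "the series" means these compounds.

Measured so far:
compound 1, `CC(C)Oc1cc(O)c2c(=O)cc(-c3ccccc3)oc2c1`, 6.24
compound 2, `CC(C)Oc1c(C(C)C)c(O)c2c(=O)cc(-c3ccccc3)oc2c1C(C)C`, 6.84
compound 3, `O=c1cc(-c2ccccc2)oc2c(Cc3ccccc3)c(O)cc(O)c12`, 6.1

In a physicochemical assay for lipophilicity (on this read-out higher numbers stand for higher lipophilicity and lower numbers for lower lipophilicity), compound 3 holds the lowest of the three numbers. Compound 1 gives 6.24, which is within the scatter of compound 3; compound 2 gives 6.84, beyond the scatter. No pair among these differs in one place only, so the numbers are reported as they stand.

Compound 4, `CC(C)=CCc1c(O)cc(O)c2c(=O)cc(-c3ccccc3)oc12`, is not yet measured. It differs from compound 3 by 2-methylprop-1-en-1-yl in place of phenyl on a saturated chain carbon bound to an aromatic carbon. For the measured compounds named here, no comparable step is available. On the four-carbon chain entering for the six-carbon ring, a step of a number 0.10 log units lower from compound 3 to compound 4 (within the scatter) is expected, that is none beyond the scatter. Compound 4 is estimated at 6, within 5.4 to 6.6.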

Compound 4, partition coefficient: 6.2
Compound 4: the middle estimate sits 0.20 log units below what was measured; the measured number falls inside the stated range.
By their numbers in this assay, from the lowest: compounds 3, 4 and 1 (each within the scatter of the next); then compound 2.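

In this assay the series now has one step read at a single place, a number 0.10 log units higher from compound 3 to compound 4 (within the scatter) for 2-methylprop-1-en-1-yl in place of phenyl on a saturated chain carbon bound to an aromatic carbon. At this place, then, the ring of six carbon atoms can give way to a ring-free chain of four carbon atoms with one double bond, and the two numbers stay within the scatter. No supporting data bear on why this step is small.

Going by these compounds, whether this holds for an amine, a carboxylic acid or a longer chain at the same place remains open. So does whether the step would be the same on the core of compound 1 or compound 2.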